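This account rests on a few compounds, and the source may have more. Where it says the series, first, only, none or still open, it means among the compounds named here.

Compound 1 `Cc1ccc(S(=O)(=O)NC2=NCCN2C(=S)SN2CCn3c2nsc3=S)cc1` in a functional assay on KYSE-510 cells (Homo sapiens) for antiproliferative activity, read by crystal violet staining, with a stated time of 96 h (a higher number here means a weaker inhibitor of growth, a lower number a stronger inhibitor of growth), gives >= 20000 nM, a limit of the assay.
Compound 2 `Cc1cc(C)c(S(=O)(=O)NC2=NCCN2C(=S)SN2CCn3c2nsc3=S)c(C)c1` in this assay gives >= 20000 nM, also a limit.
Compound 3 `COc1cc(C)ccc1S(=O)(=O)NC1=NCCN1C(=S)SN1CCn2c1nsc2=S` in this assay gives >= 20000 nM, again a limit.

Going by the values given here, compound 3 therefore stands where every measured value stands, at the limit of >= 20000 nM in this assay, at which 3 of the 3 values shown sit; no measured compound gives a number below it. Compound 4 `O=S(=O)(NC1=NCCN1C(=S)SN1CCn2c1nsc2=S)c1ccc(C(F)(F)F)cc1` differs from it by 4-(trifluoromethyl)phenyl in place of 2-methoxy-4-methylphenyl on a sulfonyl sulfur. The three measured steps, a step that the two limits leave unreadable from compound 1 to compound 2, a step that the two limits leave unreadable from compound 1 to compound 3 and a step that the two limits leave unreadable from compound 2 to compound 3, each run between two limits, so none shows a size or a direction that could carry over to this new change. In this assay an unreadable step is expected here too, a step that the limit leaves unreadable from compound 3 to compound 4. Compound 4 is estimated at 25000 nM, within 8000 nM to 80000 nM, most probably reported once more only as a limit.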

Compound 4, concentration for 50% growth inhibition: >= 20000 nM
Compound 4: no number, only a limit; the forecaster's own chance of this, stated with the estimate: 85%; the middle value is on the limit's open side.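

In this assay, going by these compounds alone, compound 4 gives only a limit, not a number, so no step to it from compound 1, compound 2 or compound 3 can be read. The compounds shown leave open whether any group on the sulfonyl sulfur changes growth inhibition, and by how much.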